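A few compounds are considered here, and "the series" means these few. Any claim that something is new, unique, unknown or untested is made for them only; others in the source may bear on it.

Measured compounds:
- compound 1 `Cc1cc(NC(=O)Cn2nnc(-c3ccccn3)n2)n(C2CCCCC2)n1` gives 14600 nM in an assay on HEK293 cells for activation of Kir3.1/Kir3.2 (Homo sapiens), read by thallium flux; a higher number here means that more compound is needed for the effect, a lower number that less compound is needed
- compound 2 `Cc1cc(NC(=O)Cn2nnc(-c3ccc(Cl)c(Cl)c3)n2)n(C2CCCCC2)n1` gives 1220 nM in this assay
- compound 3 `Cc1cc(NC(=O)Cn2nnc(-c3cc(Cl)cc(Cl)c3)n2)n(C2CCCCC2)n1` gives 980 nM in this assay

All three share the same core and differ only in the aromatic group attached to the five-membered ring with four nitrogen atoms. Compound 3 has the lowest number of the three, but its separation from compound 2 is small (a 1.2-fold lower number from compound 2 to compound 3 (0.10 log units; within the scatter)), so the two cannot be ranked. Both stand far from compound 1 (a 15-fold lower number from compound 1 to compound 3 (1.17 log units; beyond the scatter) and a 12-fold lower number from compound 1 to compound 2 (1.08 log units; beyond the scatter)), which carries the pyridin-2-yl group.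

Compound 4 `Cc1cc(NC(=O)Cn2nnc(-c3ccc(F)cc3)n2)n(C2CCCCC2)n1` has not yet been measured. Its change from compound 3 is 4-fluorophenyl in place of 3,5-dichlorophenyl on an aromatic carbon. Within the data shown here, no measured step covers a single fluorine on the phenyl ring; the steps show only that a dichlorophenyl gives a much lower number than pyridin-2-yl, and that moving chlorines between two positions changes little. A phenyl with one fluorine is expected to sit between these cases, as the data offer nothing for a phenyl with fewer halogens than compound 3, which gives 980 nM. For compound 4, a step of a 3.6-fold higher number from compound 3 to compound 4 (0.55 log units; beyond the scatter) is estimated, with a value of 3500 nM and a range from 1200 nM to 12000 nM.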

Compound 4, half-maximal effective concentration: 180 nM
The estimate for compound 4 lay 19-fold (1.29 log units) above the measured number, and the stated range ends above it.
By their numbers in this assay, from the lowest: compound 4; then compounds 3 and 2 (each within the scatter of the next); then compound 1.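

In this assay, the dichlorophenyl groups turn out not to mark the low end for this aromatic carbon on the five-membered ring, since 4-fluorophenyl goes clearly lower than 3,5-dichlorophenyl (a 5.4-fold lower number from compound 3 to compound 4 (0.74 log units; beyond the scatter)) and 3,4-dichlorophenyl (a 6.8-fold lower number from compound 2 to compound 4 (0.83 log units; beyond the scatter)), so among these compounds a second chlorine on the phenyl ring is not needed for a low number. The distance from the pyridin-2-yl group also grows well past what the chlorinated compounds showed (an 81-fold lower number from compound 1 to compound 4 (1.91 log units; beyond the scatter)), which means that this one position spans a wider range than it first seemed to. Nothing available here explains why the single fluorine does better than the two chlorines.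

From the compounds shown here alone, the step from a dichlorophenyl to 4-fluorophenyl changes the kind of halogen, the number of halogens and their places all at once, so the share of each in the drop remains unknown. A plain phenyl, or a phenyl carrying a single chlorine or a methoxy group, would be needed to start pulling these apart.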